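This account rests on a few compounds, and the source may have more. Where it says the series, first, only, none or still open, it means among the compounds named here.

Compound 1 `CC(C)(C)c1ccc(/C=C/C(=O)Nc2ccc3c(c2)OCCN3)cc1`: 16 nM
Compound 2 `Cc1ccc(/C=C/C(=O)Nc2ccc3c(c2)OCCO3)cc1`: 210 nM

In a functional assay on CHO cells for inhibition of transient receptor potential cation channel subfamily V member 1 (Homo sapiens) (on this read-out higher numbers stand for weaker inhibition and lower numbers for stronger inhibition), compound 2 stands at the higher of the two numbers, and compound 1 sits well below it, a gap beyond the scatter. Compound 3 `O=C(/C=C/c1ccc(O)cc1)Nc1ccc2c(c1)OCCO2` differs from compound 2 in one place: hydroxy in place of methyl on an aromatic carbon. Among the measured compounds shown here, no measured pair shows this exact exchange, so the direction rests on the two compounds at hand. Because compound 1 gives 16 nM with tert-butyl where compound 2 carries methyl, the step of a 5.7-fold higher number from compound 2 to compound 3 (0.76 log units; beyond the scatter) is expected to raise the number, toward weaker inhibition. Compound 3 is estimated at 1200 nM, within 300 nM to 5000 nM.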

Compound 3, half-maximal inhibitory concentration: > 4000 nM
Compound 3 gave a limit, no number; the forecaster's own chance of this, stated with the estimate: 10%; middle value at least 3.3-fold (0.52 log units) from the limit.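

On the aromatic carbon para to a large group, hydroxy in place of methyl gives a large loss of inhibition, an at least 19-fold higher number from compound 2 to compound 3 (1.27 log units; beyond the scatter). Among the compounds shown here, this is the first direct reading of a change at this position. Compound 3 gave a limit of the assay and no number, so the step is a lower bound and its full size remains unknown: the limit of > 4000 nM in this assay, at which 1 of the 3 values shown sits.

The compounds shown leave open how an amine, a methoxy group or a carboxylic acid on this carbon would fare in this assay. They also leave open whether hydroxy would cost as much on the core of compound 1.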